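The source may report more compounds than this note shows. Statements on the series, on what has been measured and on what is new or still open speak of the compounds shown alone.

Measured compounds:
- compound 1, `O=S(=O)(c1ccc(F)cc1)c1cnc2cc(F)c(Cl)cc2c1-c1ccc(Cl)cc1`: 43.7%
- compound 2, `O=S(=O)(c1ccc(F)cc1)c1cnc2cc(F)ccc2c1-c1ccc(Cl)cc1`: 91.6%

Both compounds were tested in an assay on cell membranes for displacement of a labelled ligand from metabotropic glutamate receptor 5 (Rattus norvegicus), with a stated time of 60 min, tested at 1 uM; on this read-out lower numbers stand for less inhibition and higher numbers for more inhibition at the one concentration tested (going by the name of the read-out). Among the measured compounds shown here, compound 1 gives 43.7%, which is the lowest of the two numbers; its only neighbour is compound 2, and the move is a number 47.9 percentage points higher from compound 1 to compound 2 (beyond the scatter), a gap well beyond the scatter. That one measured step removes a chloro group from the core and frees the read-out strongly.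

Compound 3, `O=S(=O)(c1ccc(F)cc1)c1cnc2ccc(Cl)cc2c1-c1ccc(Cl)cc1`, has not yet been measured. It differs from compound 1 by hydrogen in place of fluoro on an aromatic carbon; the halogen that leaves here is the fluoro, which sits on the core ortho to the chloro group that compound 1 keeps, while compound 3 keeps that chloro. For the measured compounds named here, no measured step removes a fluoro, so the only guide is the chloro removal from compound 1 to compound 2, which was large. Removing the smaller halogen is expected to move the read-out in the same direction, but by less, giving an expected a number 16.3 percentage points higher from compound 1 to compound 3 (beyond the scatter). The estimated value for compound 3 in this assay is therefore 60%, within a range from 32% to 85%.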

Compound 3, a percentage reported as inhibition, at one concentration (the size of the read-out at that concentration, not a potency): 58.3%
Compound 3: middle estimate off by 1.7 percentage points, on the high side; the range from low to high includes it.
By their numbers in this assay, from the lowest: compound 1; then compound 3; then compound 2.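

Hydrogen in place of fluoro on the shared core gives a number 14.6 percentage points higher from compound 1 to compound 3 (beyond the scatter) in this assay, a modest step but one beyond the scatter, so this position, ortho to a chloro group, also bears on the read-out. Until now, only a chloro group had been removed from the core, and that large step was a number 47.9 percentage points higher from compound 1 to compound 2 (beyond the scatter); the new step shows that losing either halogen on its own raises the number in these two pairs, although the size of the rise differs. Nothing measured here explains why either change raises the number.

The compounds shown leave open what a group other than hydrogen or fluoro would do at this position: a methoxy group, an amine or a nitrile could raise the number further or lower it. They also leave open what a core carrying neither halogen would read, and so whether the two halogen steps would simply add up or would interact.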